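A few compounds are considered here, and "the series" means these few. Any claim that something is new, unique, unknown or untested is made for them only; others in the source may bear on it.

Measured so far in an assay for inhibition of Dihydrofolate reductase (Bos taurus), at pH 7.20; on this read-out lower numbers stand for lower potency and higher numbers for higher potency (the scale is a negative logarithm):
Compound 1 `CC1(C)N=C(N)N=C(N)N1c1ccccc1N` gives 4.58.
Compound 2 `CC1(C)N=C(N)N=C(N)N1c1ccccc1O` gives 4.18.

Going by the values given here, compound 2 stands lowest of these two numbers, and its only neighbour is compound 1, reached by the single known step, a number 0.40 log units lower from compound 1 to compound 2 (beyond the scatter). Compound 3 `CC1(C)N=C(N)N=C(N)N1c1ccccc1C(F)(F)F` differs from compound 2 by trifluoromethyl in place of hydroxy on an aromatic carbon. Among the compounds with values here, no measured step swaps hydroxy for trifluoromethyl, so the one step known shows only that exchanging the group on that aromatic carbon shifts this assay modestly. For compound 3 the expected step is a number 0.22 log units higher from compound 2 to compound 3 (within the scatter), with wide uncertainty. Compound 3 is estimated at 4.4, between 3.8 and 5.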

Compound 3, logarithm of the reciprocal of the active concentration, log(1/C): 3.53
Beside the measured number, compound 3's estimate is 0.87 log units above it; measured number outside the range, below it.
By their numbers in this assay, from the lowest: compound 3; then compound 2; then compound 1.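

In this assay, this aromatic carbon now ranks three groups, with trifluoromethyl lowest: the change gives a number 0.65 log units lower from compound 2 to compound 3 (beyond the scatter), and a number 1.05 log units lower from compound 1 to compound 3 (beyond the scatter), a large step. The position can therefore lose far more than the modest amino-to-hydroxy step suggested. Nothing measured here explains the loss.

Trifluoromethyl differs from hydroxy both in heavy atoms and in having no hydrogen-bond donor or acceptor, so these compounds cannot separate the two differences. Going by these compounds, whether a methyl group, a chlorine atom or a carboxylic acid would fit this order remains open.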